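A few compounds are considered here, and "the series" means these few. Any claim that something is new, unique, unknown or untested is made for them only; others in the source may bear on it.

Compound 1 `C=C(C)CCC[C@]1(C)C2=CCC[C@](C)(CC(=O)c3ccoc3)[C@H]2CC[C@H]1C`: > 100000 nM
Compound 2 `C=C(C)CCC[C@]1(C)C2=CCC[C@](C)(C[C@@H](OC(C)=O)C3=CC(=O)OC3O)[C@H]2CC[C@H]1C`: 3500 nM

Both compounds were tested in a functional assay on HeLa cells (Homo sapiens) for antiproliferative activity, read by XTT assay, with a stated time of 72 h; a higher number here means a weaker inhibitor, a lower number a stronger inhibitor. Compound 1 gives > 100000 nM, which is a limit of the assay and not a number. Among the compounds with values here, compound 2, at 3500 nM, is the only compound so far with an actual number, so it has no measured neighbour to be ranked against.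

The next compound to be measured is compound 3 `C=C(C)CCC[C@]1(C)C2=CCC[C@](C)(C[C@@H](O)C3=CC(=O)OC3O)[C@H]2CC[C@H]1C`. It differs from compound 2 at a single place: hydrogen in place of acetyl on an oxygen on a saturated carbon. In words, this is hydrogen in place of acetyl on an oxygen on a saturated carbon, or acetoxy to hydroxy. The rest of the structure stays the same.

Within the data shown here, no measured pair here shows this change, so any forecast is uncertain and the range must stay wide. With compound 2 at 3500 nM as the only anchor, the expectation stays close to that value. The expected change is a 1.2-fold lower number from compound 2 to compound 3 (0.07 log units; within the scatter), with no shift in either direction beyond the usual scatter. For compound 3 the estimated value is 3000 nM, with an expected range of 900 nM to 10000 nM.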

Compound 3, half-maximal inhibitory concentration: 2600 nM
Estimate against measurement, compound 3: 1.2-fold (0.06 log units) above; the range from low to high includes it.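

In this assay, the acetyl on this oxygen is not required for activity: with hydrogen in its place, leaving a hydroxy group, the outcome is a 1.3-fold lower number from compound 2 to compound 3 (0.13 log units; within the scatter), so compound 2 and compound 3 cannot be told apart here. The group on the saturated chain carbon bound to a saturated ring carbon matters far more, as replacing the five-membered aromatic ring group of compound 1 with the five-membered non-aromatic ring group of compound 3 gives an at least 38-fold lower number from compound 1 to compound 3 (1.58 log units; beyond the scatter). That step has a limit of the assay at one end and not a number, so its true size is unknown: the limit of > 100000 nM in this assay, at which 1 of the 3 values shown sits.

On these data alone, whether a methyl ether or a longer ester on this oxygen would give a similar value stays open, as does the effect of an amine on the same saturated carbon. Also open is which part of the non-aromatic ring group accounts for the step from compound 1, as that single swap alters several atoms at once, and a version with the ring hydroxy replaced by a methoxy group would be one way to probe this.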